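The source may report more compounds than this note shows. Statements on the series, on what has been measured and on what is new or still open speak of the compounds shown alone.

Compound 1 `COc1ccc(/C(=C(/CCCl)c2ccccc2)c2ccccc2)cc1`, compound 2 `COc1ccc(/C(=C(/CCN)c2ccccc2)c2ccccc2)cc1` and compound 3 `COc1ccc(/C(=C(/CCNC(=O)Oc2ccccc2)c2ccccc2)c2ccccc2)cc1` share one core, and compound 4 `CCOC(=O)C(=O)NCC/C(=C(\c1ccccc1)c1ccc(OC)cc1)c1ccccc1` is the next member to be examined. In a functional assay on MCF7 cells (Homo sapiens) for cytotoxicity, read by MTT assay, with a stated time of 72 h (on this read-out higher numbers stand for weaker inhibition and lower numbers for stronger inhibition), compound 1 reaches only a limit of the assay, > 50000 nM. Compound 2 gives 16900 nM in this assay. Within the data shown here, the one measured step that changes a single place, an at least 2.9-fold lower number from compound 1 to compound 2 (0.47 log units; beyond the scatter), is the sole guide to this series. Compound 3 is reported in this assay as "not active" (no number reported), so no number places it among the others; of the three values shown, one sits at the limit of > 50000 nM in this assay, at which 1 of the 3 values shown sits. The change ethoxycarbonyl in place of phenoxy on a carbonyl carbon keeps the amide-type nitrogen and its carbonyl and alters only the group hanging on that carbonyl carbon. No measured step touches that position, and the only step shown concerns the chain end rather than what hangs on the carbonyl. Compound 4 is therefore expected to remain weak in this assay, near 30000 nM, within 8000 nM to 50000 nM, with a fair chance that only a limit is reported.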

Compound 4, half-maximal inhibitory concentration: > 50000 nM
Compound 4 was reported as a limit (the forecaster's own chance of this, stated with the estimate: 50%); at least 1.6-fold (0.22 log units) between middle value and limit.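

Putting (ethoxycarbonyl)carbonyl in place of hydrogen on the amine nitrogen gives an at least 2.9-fold higher number from compound 2 to compound 4 (0.47 log units; beyond the scatter) in this assay, so a substituent on that nitrogen can separate a compound from the free amine of compound 2. Compound 4 stands at a limit of the assay, and the step from compound 1 can't be read because both compounds are limits. Changing phenoxy to ethoxycarbonyl on the carbonyl carbon gives no number either, since compound 3 is reported as not active and compound 4 reaches only a limit, and the values shown gather at one end: the limit of > 50000 nM in this assay, at which 2 of the 4 values shown sit.

The compounds shown leave open whether any group on that carbonyl carbon can restore a measurable value in this assay. A carboxylic acid in place of the ethyl ester, a simple acetyl group on the nitrogen, or a longer chain bearing the free amine remains unplaced.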